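A few compounds are considered here, and "the series" means these few. Any claim that something is new, unique, unknown or untested is made for them only; others in the source may bear on it.

Measured compounds:
compound 1, `CCC(C)n1ncn(-c2ccc(N3CCN(c4ccc(OC[C@@H]5COC(c6ccc(Cl)cc6Cl)O5)cc4)CC3)cc2)c1=O`, gives 328 nM
compound 2, `CCC(C)n1ncn(-c2ccc(N3CCN(c4ccc(OC[C@@H]5CO[C@@](CC6CCCC6)(c6ccc(Cl)cc6Cl)O5)cc4)CC3)cc2)c1=O`, gives 512 nM
compound 3, `CCC(C)n1ncn(-c2ccc(N3CCN(c4ccc(OC[C@@H]5CO[C@@](Cn6cnc(C)n6)(c6ccc(Cl)cc6Cl)O5)cc4)CC3)cc2)c1=O`, gives 272 nM

In a functional assay on HUVEC cells (Homo sapiens), read by scintillation counting and thymidine incorporation, with a stated time of 24 h (a higher number here means a weaker inhibitor, a lower number a stronger inhibitor), compound 3 gives 272 nM, the lowest of the three numbers, yet its distance to the other two is small: compound 1 at 328 nM lies within the scatter of it, and compound 2 at 512 nM lies within the scatter as well. Among the compounds with values here, on these numbers no compound can be set apart from the others.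

The next compound, compound 4, `CCC(C)n1ncn(-c2ccc(N3CCN(c4ccc(OC[C@@H]5CO[C@@](Cn6cc(C(F)(F)F)nc6C)(c6ccc(Cl)cc6Cl)O5)cc4)CC3)cc2)c1=O`, differs from compound 3 in one place: 2-methyl-4-(trifluoromethyl)-1H-imidazol-1-yl in place of 3-methyl-1H-1,2,4-triazol-1-yl on a saturated chain carbon bound to a saturated ring carbon.

Within the data shown here, one measured step bears on this change, since it sits at the same place on the same chain carbon: a 1.9-fold lower number from compound 2 to compound 3 (0.27 log units; within the scatter). That exchange of a cyclopentyl for a 3-methyl-1H-1,2,4-triazol-1-yl stayed within the scatter, so a further swap of one five-membered aromatic ring for another at this position gives no ground to expect a move beyond the scatter in either direction.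

Compound 4 is therefore expected to give about 300 nM, with a likely range from 120 nM to 750 nM. The expected step is a 1.1-fold higher number from compound 3 to compound 4 (0.04 log units; within the scatter).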

Compound 4, half-maximal inhibitory concentration: 441 nM
For compound 4 the middle estimate is 1.5-fold (0.17 log units) below the measured one; the range from low to high includes it.
By their numbers in this assay, from the lowest: compounds 3, 1, 4 and 2 (each within the scatter of the next).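

In this assay, replacing 3-methyl-1H-1,2,4-triazol-1-yl with 2-methyl-4-(trifluoromethyl)-1H-imidazol-1-yl gives a 1.6-fold higher number from compound 3 to compound 4 (0.21 log units; within the scatter), and replacing cyclopentyl with the same imidazole group gives a 1.2-fold lower number from compound 2 to compound 4 (0.06 log units; within the scatter). Until now, a single exchange on this saturated chain carbon bound to a saturated ring carbon had been seen; the three groups now compared are a saturated carbocycle, a triazole and a trifluoromethyl-bearing imidazole, and their pairwise steps all stay within the scatter, even though the entering group has 10 heavy atoms against 6 for the triazole group it replaces and includes fluorine. The compounds therefore show that this position tolerates these three groups in this assay without a measurable separation among them, and no measured information is available to explain that result.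

On these data alone, what remains open is whether any group at this place can move the number beyond the scatter, since all the groups compared here are uncharged rings attached through the chain carbon. An amine, a carboxylic acid or a longer chain bearing one of these rings could test that, and the present compounds give no indication of the outcome.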